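This account rests on a few compounds, and the source may have more. Where it says the series, first, only, none or still open, it means among the compounds named here.

Within the data shown here, in a functional assay on MDA-MB-231 cells (Homo sapiens) for cytotoxicity, read by MTT assay, with a stated time of 96 h (on this read-out lower numbers stand for stronger inhibition and higher numbers for weaker inhibition), three compounds on a shared core have numbers so far. Compound 1 `CC[C@H](N)C(=O)N[C@@H]1C(=O)N2[C@@H](CC[C@@H]1CNC(=O)NCc1ccccc1)CC[C@H]2C(=O)NC(c1ccccc1)c1ccccc1` gives 3400 nM, compound 2 `CC[C@H](N)C(=O)N[C@@H]1C(=O)N2[C@@H](CC[C@@H]1CCN)CC[C@H]2C(=O)NC(c1ccccc1)c1ccccc1` gives 12900 nM and compound 3 `CC[C@H](N)C(=O)N[C@@H]1C(=O)N2[C@@H](CC[C@@H]1CCO)CC[C@H]2C(=O)NC(c1ccccc1)c1ccccc1` gives 1800 nM. Compound 3 sits level with compound 1, the record showing a 1.9-fold lower number from compound 1 to compound 3 (0.28 log units; within the scatter). Compound 2 stands apart from both, with a 3.8-fold higher number from compound 1 to compound 2 (0.58 log units; beyond the scatter) and a 7.2-fold lower number from compound 2 to compound 3 (0.86 log units; beyond the scatter).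

Compound 4 `CC[C@H](N)C(=O)N[C@@H]1C(=O)N2[C@@H](CC[C@@H]1CCNC(=O)c1ccccc1)CC[C@H]2C(=O)NC(c1ccccc1)c1ccccc1` has not yet been measured. Its difference from compound 3 is benzamido in place of hydroxy on a saturated chain carbon, two bonds along the chain from a saturated ring carbon. Among the measured compounds shown here, no measured step makes exactly this change. The closest guide is compound 1, which also carries a carbonyl and an aromatic ring in its side group and gives 3400 nM. In this assay, the expected outcome is therefore no change beyond the scatter, with the estimated step being a 1.7-fold higher number from compound 3 to compound 4 (0.22 log units; within the scatter). For compound 4 the estimated value is 3000 nM, with an expected range from 1200 nM to 8000 nM.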

Compound 4, half-maximal inhibitory concentration: 930 nM
The estimate for compound 4 lay 3.2-fold (0.51 log units) above the measured number; measured number below the stated range.
By their numbers in this assay, from the lowest: compounds 4, 3 and 1 (each within the scatter of the next, the first and the last beyond it); then compound 2.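

In this assay, the change from hydroxy to benzamido at this place on the chain leaves the number within the scatter, with a 1.9-fold lower number from compound 3 to compound 4 (0.29 log units; within the scatter), so this much larger group, with its aromatic ring, is accommodated here without a loss. Putting benzoyl on the amine nitrogen gives the largest step in the series, a 14-fold lower number from compound 2 to compound 4 (1.14 log units; beyond the scatter), which sets the free amine of compound 2 apart from the hydroxy and benzamido side groups. The side groups of compound 1 and compound 4 both hold a carbonyl and an aromatic ring, yet a 3.7-fold lower number from compound 1 to compound 4 (0.56 log units; beyond the scatter) lies beyond the scatter, so those two features alone do not fix the number.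

No available evidence accounts for the size of these steps. The compounds shown leave open whether an acetamido group, which lacks the aromatic ring, or a longer chain carrying the benzamido group would give a similar number.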